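This account rests on a few compounds, and the source may have more. Where it says the series, first, only, none or still open, it means among the compounds named here.

Measured so far in a functional assay on cells for antagonist activity at C-X-C chemokine receptor type 4 (Homo sapiens), read by fluorescence and calcium flux, with stated times of 25 min and 90 s; on this read-out lower numbers stand for stronger inhibition and higher numbers for weaker inhibition:
Compound 1, `c1ccc(CNCCCCN(C[C@H]2Cc3ccccc3CN2)[C@H]2CCCc3cccnc32)cc1`, gives 20.1 nM.
Compound 2, `c1ccc2c(c1)CN[C@@H](CN(CCCCNCC1CCOCC1)[C@H]1CCCc3cccnc31)C2`, gives 52.9 nM.
Compound 3, `c1ccc2c(c1)CN[C@@H](CN(CCCCNC1CCNCC1)[C@H]1CCCc3cccnc31)C2`, gives 63.4 nM.

Compound 1 gives the lowest number of the three, and both of its steps to the other two lie beyond the scatter: a 2.6-fold higher number from compound 1 to compound 2 (0.42 log units; beyond the scatter) and a 3.2-fold higher number from compound 1 to compound 3 (0.50 log units; beyond the scatter). Between compound 2 and compound 3 the gap is within the scatter: a 1.2-fold higher number from compound 2 to compound 3 (0.08 log units; within the scatter).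

Compound 4, `CC(C)(CN)CCN(C[C@H]1Cc2ccccc2CN1)[C@H]1CCCc2cccnc21`, has not yet been tested. It differs from compound 1 in one place: 1-(aminomethyl)-1-methylethyl in place of 2-(benzylamino)ethyl on a saturated chain carbon, two bonds along the chain from an amine nitrogen. The two measured steps from compound 1 bear on this change. Each of them also replaces the benzyl or phenyl part of the same chain while leaving the rest of compound 1 untouched, and each raised the number by a modest amount beyond the scatter. The change to compound 4 goes further than either: the whole 2-(benzylamino)ethyl piece leaves, and the smaller 1-(aminomethyl)-1-methylethyl enters. A step in the same direction, toward weaker inhibition, is the expected outcome, and it is expected to be at least as large as the larger of the two measured ones, a 10-fold higher number from compound 1 to compound 4 (1.00 log units; beyond the scatter). Compound 4 is therefore estimated at 200 nM, with a likely range from 50 nM to 800 nM.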

Compound 4, half-maximal inhibitory concentration: 69 nM
Beside the measured number, compound 4's estimate is 2.9-fold (0.46 log units) above it; the measured number falls inside the stated range.
By their numbers in this assay, from the lowest: compound 1; then compounds 2, 3 and 4 (each within the scatter of the next).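

In this assay, for the compounds shown here, the earlier compounds only exchanged one ring at the end of the chain for another, whereas compound 4 has no ring there at all: the 10 heavy atoms of 2-(benzylamino)ethyl give way to the 5 of 1-(aminomethyl)-1-methylethyl, and the cost is still only a 3.4-fold higher number from compound 1 to compound 4 (0.54 log units; beyond the scatter). That change leaves compound 4 level with both ring-bearing compounds, with a 1.1-fold higher number from compound 3 to compound 4 (0.04 log units; within the scatter) and a 1.3-fold higher number from compound 2 to compound 4 (0.12 log units; within the scatter), so among these four compounds a ring in this group is not required to reach this level, and only compound 1, with its benzyl group, gives a lower number. Nothing available explains why compound 1 stays lowest or why the other three sit so close together.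

The compounds shown leave open whether the terminal amine of compound 4 matters, which a hydroxyl or a carboxylic acid in its place would test. They also leave open whether the branching matters, which an unbranched 4-aminobutyl chain on the same nitrogen would test.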